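A few compounds are considered here, and "the series" means these few. Any claim that something is new, unique, unknown or untested is made for them only; others in the source may bear on it.

Working notes on the series in a functional assay on L5178Y cells (Mus musculus) for inhibition, read by MTT assay, with a stated time of 24 h; a lower number here means a stronger inhibitor, a higher number a weaker inhibitor. Compound 1 `Oc1ccc([C@@H]2C/C(=N\Nc3cnccn3)c3c(O)cc(O)cc3O2)cc1` gives >= 11300 nM, which is a limit. Compound 2 `Cn1cccc1/C=N/N=C1\C[C@@H](c2ccc(O)cc2)Oc2cc(O)cc(O)c21` gives >= 11300 nM, also a limit. Compound 3 `O=C(N/N=C1\C[C@@H](c2ccc(O)cc2)Oc2cc(O)cc(O)c21)OCc1ccccc1` gives >= 11300 nM, again a limit and not a number. It therefore stands with the other two, as the limit of >= 11300 nM in this assay, at which 3 of the 3 values shown sit, shows.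

Compound 4 `CN(C)C(=S)N/N=C1\C[C@@H](c2ccc(O)cc2)Oc2cc(O)cc(O)c21` differs from compound 3 on the amine nitrogen: a group of 5 heavy atoms (3 carbon, 1 nitrogen, 1 sulfur; no ring) in place of a group of 10 heavy atoms (8 carbon, 2 oxygen; one six-membered aromatic ring of carbon only), on an amine nitrogen. The benzyloxycarbonyl group leaves with its aromatic ring, and the entering group has no ring.

The steps bearing on this change are a step that the two limits leave unreadable from compound 1 to compound 3 and a step that the two limits leave unreadable from compound 1 to compound 2. Within the data shown here, neither has a size that can be carried over, so no step of definite size or direction is expected. Among the measured compounds shown here, compound 4 is expected to stay near the same limit, although its entering group has no counterpart among the measured compounds, which leaves a real chance of a number. The estimated change is an at least 1.0-fold lower number from compound 3 to compound 4 (0.01 log units; that floor lies within the scatter). For compound 4 the expected value is 11000 nM, with an estimated range of 2500 nM to 25000 nM.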

Compound 4, half-maximal inhibitory concentration: >= 11300 nM
Compound 4 was reported as a limit; the forecaster's own chance of this, stated with the estimate: 65%; at least 1.0-fold (0.01 log units) between middle value and limit.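

In this assay compound 4 gives >= 11300 nM, which is a limit. No step from compound 1, compound 2 or compound 3 to compound 4 can be read, and the four compounds stand together: the limit of >= 11300 nM in this assay, at which 4 of the 4 values shown sit.

The compounds shown leave open which group, if any, on the shared core would give a number rather than a limit.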